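A few compounds are considered here, and "the series" means these few. Any claim that something is new, unique, unknown or untested is made for them only; others in the source may bear on it.

Measured compounds in this series:

compound 1 `c1ccc(C2CCN(Cc3nc4ccccc4[nH]3)CC2)nc1` — 12 nM
compound 2 `Cc1cccc(C(=O)NCN2CCC(c3ccccn3)CC2)c1` — 9 nM
compound 3 `Cc1cccc(C(=O)NCN2CCC(c3cccc[n+]3[O-])CC2)c1` — 89 nM

In a functional assay on HEK293 cells for agonist activity at D(4) dopamine receptor (Homo sapiens), read by FLIPR (a higher number here means that more compound is needed for the effect, a lower number that less compound is needed), compound 2 gives 9 nM and compound 3 gives 89 nM. Among the compounds with values here, the two compounds share their core, and the only change between them is a group of 7 heavy atoms (5 carbon, 1 nitrogen, 1 oxygen; one six-membered aromatic ring with 1 hetero atom) in place of a group of 6 heavy atoms (5 carbon, 1 nitrogen; one six-membered aromatic ring with 1 hetero atom), on a saturated ring carbon. Within the data shown here, that change made the step of a 9.9-fold higher number from compound 2 to compound 3 (1.00 log units; beyond the scatter), the one clearly resolved step among the three measured compounds.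

Compound 1 gives 12 nM in this assay, which puts it within the scatter of compound 2; the difference between the cores of compound 1 and compound 2 is not broken down here, as they differ in more than one place.

Compound 4 `[O-][n+]1ccccc1C1CCN(Cc2nc3ccccc3[nH]2)CC1` has not yet been measured. It differs from compound 1 by a group of 7 heavy atoms (5 carbon, 1 nitrogen, 1 oxygen; one six-membered aromatic ring with 1 hetero atom) in place of a group of 6 heavy atoms (5 carbon, 1 nitrogen; one six-membered aromatic ring with 1 hetero atom), on a saturated ring carbon, and the place is the same, word for word, as in the change from compound 2 to compound 3, so this is the same change made on the core of compound 1. As compound 1 and compound 2 sit within the scatter of each other in this assay, the measured step from compound 2 to compound 3 is taken as the best guide for what the change will do on compound 1. The expected step is a 9.2-fold higher number from compound 1 to compound 4 (0.96 log units; beyond the scatter), resting on the step of a 9.9-fold higher number from compound 2 to compound 3 (1.00 log units; beyond the scatter). Compound 4 is therefore estimated at 110 nM in this assay, with the expected range running from 40 nM to 350 nM; whether the change carries over unchanged to the core of compound 1 is the open question this measurement will settle.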

Compound 4, half-maximal effective concentration: 54 nM
Beside the measured number, compound 4's estimate is 2.0-fold (0.31 log units) above it; the measured number falls inside the stated range.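

In this assay, putting the entering group in place of pyridin-2-yl on the saturated ring carbon of the core of compound 1 gives a 4.5-fold higher number from compound 1 to compound 4 (0.65 log units; beyond the scatter), so the change raises the number on this core as well. The two measured cases point the same way, and their sizes cannot be told apart, so on these two cores the change can be treated as one step of a shared size: the same change on two cores in this assay, a 9.9-fold higher number (1.00 log units; beyond the scatter) from compound 2 to compound 3 and a 4.5-fold higher number (0.65 log units; beyond the scatter) from compound 1 to compound 4, 2.2-fold (0.34 log units) apart, within the scatter of two such steps. This shows transfer across two cores and one change only; it does not show that the step would hold on any further core, it cannot settle whether the smaller number on the core of compound 1 is a real difference, and it gives no reason for the rise.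

Still open, going by these compounds, is whether the step survives when the pyridin-2-yl ring carries a further group such as a methyl or a chlorine, or when a plain phenyl stands in its place on the saturated ring carbon. Also open, on these data alone, is how the step behaves on cores with a longer chain or a carboxylic acid on the ring nitrogen, and whether anything seen in this assay extends to other read-outs.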